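Compound 3 to compound 4: a step behind a limit

The source may hold more compounds than are shown below. What is called first, only, known or untested is meant among the compounds shown, and "the series" means these compounds.

In a functional assay on the whole organism for antagonist activity, with Mus musculus as the target, in the maximal electroshock model (a lower number here means that less compound is needed, a higher number that more compound is needed for the effect), compound 1 `CCS(=O)(=O)c1nnc(-c2ccccc2)n1C` gives > 200 mg/kg, which is a limit of the assay and not a number. Compound 2 `CSc1nnc(-c2cccc3ccccc23)n1C` gives > 200 mg/kg, also a limit. Compound 3 `Cn1c(-c2cccc3ccccc23)nnc1[S+](C)[O-]` gives > 200 mg/kg, again a limit. Compound 3 therefore stands with the other two at the limit of > 200 mg/kg in this assay, at which 3 of the 3 values shown sit.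

Compound 4 `Cn1c(-c2cccc3ccccc23)nnc1S(C)(=O)=O` carries methylsulfonyl on an aromatic carbon of a five-membered aromatic ring with 3 nitrogen, in place of the group with no common name in compound 3: a group of 4 heavy atoms (1 carbon, 2 oxygen, 1 sulfur; no ring) in place of a group of 3 heavy atoms (1 carbon, 1 oxygen, 1 sulfur; no ring), on an aromatic carbon. Among the compounds with values here, the one measured step that bears on this change is a step that the two limits leave unreadable from compound 2 to compound 3, and it offers no size to carry over. No readable shift in either direction can thus be predicted in this assay, and the most likely outcome is expected to be another limit. The estimated change is a step that the limit leaves unreadable from compound 3 to compound 4, with no direction beyond the scatter intended. Compound 4 is expected at 250 mg/kg, within an estimated range of 100 mg/kg to 500 mg/kg.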

Compound 4, dose for half-maximal effect: > 200 mg/kg
Compound 4: no number, only a limit; the forecaster's own chance of this, stated with the estimate: 75%; the middle value is on the limit's open side.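

Within the data shown here, compound 4 gives > 200 mg/kg, which is a limit of the assay and not a number, and no step to compound 4 from compound 2 or compound 3 can be read. The compounds shown leave open whether methylsulfanyl, methylsulfonyl or the group in compound 3 differ at all in this assay, since all values sit at one limit: the limit of > 200 mg/kg in this assay, at which 4 of the 4 values shown sit.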